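The source may report more compounds than this note shows. Statements on the series, on what has been measured and on what is new or still open speak of the compounds shown alone.

Compound 1 `O=C1Nc2ccc(Br)cc2/C1=C/c1cccc(OCc2cn(Cc3ccccc3)nn2)c1` is reported in a functional assay on HeLa cells (Homo sapiens) for inhibition, read by MTT assay, with a stated time of 48 h (a higher number here means a weaker inhibitor, a lower number a stronger inhibitor), only as a limit, > 50000 nM. Compound 2 `CC(=O)c1ccc2c(c1)/C(=C/c1cccc(OCc3cn(Cc4ccccc4)nn3)c1)C(=O)N2` likewise gives a limit in this assay, > 50000 nM. Compound 3 `CC(=O)c1ccc2c(c1)/C(=C\c1cccc(OCc3cn(Cc4ccccc4)nn3)c1)C(=O)N2` also gives a limit in this assay, > 50000 nM.

Compound 2 thus stands at the limit, together with the other two measured compounds, as the limit of > 50000 nM in this assay, at which 3 of the 3 values shown sit, shows. The step to compound 4 `COc1ccc(Cc2ccc3c(c2)/C(=C/c2cccc(OCc4cn(Cc5ccccc5)nn4)c2)C(=O)N3)cc1` is 4-methoxybenzyl in place of acetyl on an aromatic carbon. The two measured steps that bear on it, a step that the two limits leave unreadable from compound 1 to compound 2 and a step that the two limits leave unreadable from compound 2 to compound 3, both run between limits and so give no readable size; this holds even for the pair that, per (the fact that compounds 2 and 3 differ only in the configuration as drawn), differs only in drawn configuration. No measured change has moved any compound off the limit, so compound 4 is expected to sit there as well, giving an estimate of 60000 nM (range 15000 nM to 250000 nM). The step from compound 2 to compound 4 is accordingly estimated as a step that the limit leaves unreadable from compound 2 to compound 4, within the scatter.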

Compound 4, half-maximal inhibitory concentration: 7700 nM
Estimate against measurement, compound 4: 7.8-fold (0.89 log units) above; the whole stated range lies above it.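

In this assay, the position on the aromatic carbon turns out to respond to the group it carries: 4-methoxybenzyl in place of acetyl gives an at least 6.4-fold lower number from compound 2 to compound 4 (0.81 log units; beyond the scatter). In place of bromo at the same place, it gives an at least 6.4-fold lower number from compound 1 to compound 4 (0.81 log units; beyond the scatter). Compound 4 is the only compound shown that comes off the limit, so this series now has its first readable number: the limit of > 50000 nM in this assay, at which 3 of the 4 values shown sit.

Going by these compounds, both steps start from a limit, so their true sizes stay open, and the steps among compounds 1, 2 and 3 cannot be read. On these data alone, it also stays open whether the methoxy matters, as a plain benzyl or an amine at this place could tell, and how the opposite double-bond configuration of compound 4 would read.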